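A few compounds are considered here, and "the series" means these few. Any claim that something is new, unique, unknown or untested is made for them only; others in the source may bear on it.

Working notes on the series.

Compound 1 `CCCc1nc(CC)c(C(=O)OCCCOCc2ccccc2)n1Cc1ccc(-c2ccccc2S(=O)(=O)NC(=O)OCCC(C)C)cc1F` is tested in an assay on isolated protein for binding affinity to Type-2 angiotensin II receptor (Homo sapiens) (a lower number here means a stronger inhibitor, a higher number a weaker inhibitor), and gives 2 nM. Two other members of the series have been measured. Compound 2 `CCCOC(=O)NS(=O)(=O)c1ccccc1-c1ccc(Cn2c(CCC)nc(CC)c2C(=O)OCc2cccc(C(=O)c3ccccc3)c2)c(F)c1` gives 10 nM in this assay, and compound 3 `CCCc1nc(CC)c(C(=O)OCc2ccccc2C(=O)c2ccccc2)n1Cc1ccc(-c2ccccc2S(=O)(=O)NC(=O)OCCc2ccccc2)cc1F` gives 0.69 nM. Among these three numbers compound 1 stands second highest: compound 3 lies below it by a gap beyond the scatter, and compound 2 lies above it by a gap beyond the scatter. The two compounds that flank compound 1 differ from it in more than one place, so no single step can be read from them.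

Compound 4 `CCCc1nc(CC)c(C(=O)NCCCOc2ccccc2)n1Cc1ccc(-c2ccccc2S(=O)(=O)NC(=O)OCCC(C)C)cc1F` has not yet been measured. It differs from compound 1 in one place, on a carbonyl carbon whose other neighbour is an aromatic carbon: (3-phenoxypropyl)amino in place of 3-(benzyloxy)propoxy on a carbonyl carbon. Going by the values given here, no measured pair shows this change, so the step from compound 1 to compound 4 is expected to be a modest weakening in this assay, a 3.0-fold higher number from compound 1 to compound 4 (0.48 log units; beyond the scatter), with an outcome of no change beyond the scatter also plausible. Compound 4 is therefore expected to give 6 nM in this assay, within a range from 1.5 nM to 25 nM.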

Compound 4, half-maximal inhibitory concentration: 9 nM
Beside the measured number, compound 4's estimate is 1.5-fold (0.18 log units) below it; the range from low to high includes it.
By their numbers in this assay, from the lowest: compound 3; then compound 1; then compounds 4 and 2 (each within the scatter of the next).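

Going by these compounds alone, the first single-place reading at this position is (3-phenoxypropyl)amino in place of 3-(benzyloxy)propoxy on a carbonyl carbon, and in this assay it gives a 4.5-fold higher number from compound 1 to compound 4 (0.65 log units; beyond the scatter). The entering group keeps one six-membered aromatic ring but brings a hydrogen-bond donor that the leaving group lacks, and the exchange alters both the atom on the carbonyl carbon and the ether part of the chain. No available data explain the higher number.

The compounds shown do not separate the contribution of the amide hydrogen from that of the phenoxy ether, since a 3-phenoxypropoxy or (3-(benzyloxy)propyl)amino group does not appear among them. Going by these compounds, how a carboxylic acid or a longer ether chain on this carbonyl carbon would compare with compound 1 also remains open.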